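Amino for Hydrogen on a Chlorinated Purine Scaffold

This account rests on a few compounds, and the source may have more. Where it says the series, first, only, none or still open, it means among the compounds named here.

Measured so far:
compound 1 `ClCc1ccc(Cn2cnc3c(Cl)ncnc32)cc1` — "not determined" (no result reported)
compound 2 `ClCc1cccc(Cn2cnc3c(Cl)nc(Cl)nc32)c1` — 2040 nM
compound 3 `Nc1nc(Cl)c2ncn(Cc3ccccc3CCl)c2n1` — 8130 nM

As far as these compounds go, in a functional assay on SNB-75 cells (Homo sapiens) for cytotoxicity, read by sulforhodamine B assay, with a stated time of 48 h (on this read-out higher numbers stand for weaker inhibition of growth and lower numbers for stronger inhibition of growth), compound 1 is recorded as "not determined" (no result reported), so its standing on this read-out is unknown. Compound 2 gives 2040 nM in this assay. Compound 3 gives 8130 nM in this assay. Compound 4 `Nc1nc(Cl)c2ncn(Cc3ccc(CCl)cc3)c2n1` differs from compound 1 by amino in place of hydrogen on an aromatic carbon. Going by the values given here, since no measured pair spans this change, the size and direction of the step in this assay cannot be taken from a step; the account rests on the values of compound 2 and compound 3 alone. Compound 4 is expected to fall near 7000 nM, with a range from 2500 nM to 20000 nM.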

Compound 4, concentration for 50% growth inhibition: 22900 nM
Compound 4: the middle estimate sits 3.3-fold (0.51 log units) below what was measured; measured number above the stated range.
By their numbers in this assay, from the lowest: compound 2; then compound 3; then compound 4.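

No step can be read between compound 1 and compound 4 from these results. The compounds shown leave open what amino in place of hydrogen does to growth inhibition on the shared core. No evidence at hand bears on the result for compound 4.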